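The source may report more compounds than this note shows. Statements on the series, on what has been measured and on what is new or still open speak of the compounds shown alone.

Measured so far:
- compound 1, `CCC(C(=O)N1CCOCC1)N1C(=O)CCC1=O`: 0%
- compound 2, `CC(C(=O)N1CCN(c2ccc(F)cc2)CC1)N1C(=O)CCC1=O`: 25%
- compound 3, `CC(C(=O)N1CCN(c2ccc(C(F)(F)F)cc2)CC1)N1C(=O)CCC1=O`: 0%

All three were tested in a functional assay on the whole organism (strain Swiss) with Mus musculus as the target, in the maximal electroshock model, with a stated time of 1 h, at a dose of 300 mg/kg by the intraperitoneal route; a lower number here means a weaker effect, a higher number a stronger effect of the compound at the dose given. On these numbers compound 2 stands highest of the three: compound 1 is lower by a margin beyond the usual scatter, and compound 3 is lower by the same margin, so compound 2 is the only one of the three that shows a clear effect.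

Compound 4, `Cc1cccc(N2CCN(C(=O)C(C)N3C(=O)CCC3=O)CC2)c1`, is reached from compound 2 by a single change on the shared core: 3-methylphenyl in place of 4-fluorophenyl on an amine nitrogen in a ring. Among the measured compounds shown here, only one measured step touches the same ring. From compound 2 to compound 3 the fluoro was replaced by trifluoromethyl, and the result was a number 25 percentage points lower from compound 2 to compound 3 (beyond the scatter), which took the effect away entirely. For the measured compounds named here, no measured compound carries a methyl on that ring, so the new group itself is untested. Given that the one known swap on this ring lowered the result, a downward step in this assay is expected for compound 4 as well, estimated as a number 15 percentage points lower from compound 2 to compound 4 (beyond the scatter). The value for compound 4 is therefore expected near 10%, in the range 0% to 35%.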

Compound 4, a percentage reported as activity, at one dose (the size of the read-out at that dose, not a potency): 0%
Compound 4: the middle estimate sits 10 percentage points above what was measured, and the stated range covers the measured number.
By their numbers in this assay, from the lowest: compounds 1, 3 and 4 (each within the scatter of the next); then compound 2.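

The step of a number 25 percentage points lower from compound 2 to compound 4 (beyond the scatter) in this assay shows that a second replacement of the 4-fluorophenyl group also removes the effect, and the incoming 3-methylphenyl is no larger by count, with 7 heavy atoms in each group. Among the compounds shown, a clear effect with this type of group on the amine nitrogen in a ring appears only with 4-fluorophenyl, so the earlier loss with trifluoromethyl is no longer an isolated case. Nothing measured here explains the loss.

This change swaps the fluoro for a methyl and alters the printed location on the phenyl ring at once, so compound 4 cannot separate the two; 4-methylphenyl and 3-fluorophenyl would. A plain phenyl or a 4-chlorophenyl group would test whether the effect of compound 2 depends on fluoro specifically.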